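The source may hold more compounds than are shown below. What is called first, only, known or untested is meant among the compounds shown, and "the series" means these compounds.

Compound 1 `CSc1nccc2c1ncn2C1O[C@H](CO)[C@@H](O)[C@H]1O` belongs to a small set of nucleoside-like compounds tested in a functional assay on EL4 cells (Mus musculus) for inhibition, tested at 100 uM; on this read-out lower numbers stand for less inhibition and higher numbers for more inhibition at the one concentration tested (going by the name of the read-out). For compound 1 the assay reports only a limit, < 5%, and not a number. Compound 2 `CSc1nccc2c1ncn2[C@H]1C[C@H](O)[C@@H](CO)O1` likewise sits at a limit, < 5%. Going by the values given here, compound 3 `C[C@H]1OC(n2cnc3c(N)nccc32)[C@H](O)[C@@H]1O` is the one member that gives a read-out, with 32%. Compound 1 therefore stands at the bottom of what is seen, sharing the limit of < 5% in this assay, at which 2 of the 3 values shown sit, with compound 2, while compound 3 lies above both.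

The next compound, compound 4 `CCCCCCNc1nccc2c1ncn2C1O[C@H](CO)[C@@H](O)[C@H]1O`, keeps the sugar and the shared core of compound 1 and changes one place: hexylamino in place of methylsulfanyl on an aromatic carbon. Among the compounds with values here, no step between two measured compounds that differ in only one place is available, so nothing shows directly how this assay responds to a change at that carbon. Within the data shown here, the one hint is that the only measured compound carrying an amino group, compound 3, gives 32%. On that slender footing a modest rise from compound 1 to compound 4, at about the edge of the usual scatter, is the expectation, written as a number at least 10 percentage points higher from compound 1 to compound 4 (that floor lies within the scatter), with a wide range on both sides. For compound 4 the estimate is therefore 15%, between 0% and 45%.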

Compound 4, a percentage reported as inhibition, at one concentration (the size of the read-out at that concentration, not a potency): 14%
For compound 4 the middle estimate is 1 percentage points above the measured one; the measured number falls inside the stated range.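

Going by these compounds alone, this pair gives the first direct look at the aromatic carbon next to the ring nitrogen, where a small group, methylsulfanyl, gives way to a much larger one that also brings a hydrogen-bond donor. In this assay, the exchange for hexylamino gives a number at least 9 percentage points higher from compound 1 to compound 4 (that floor lies within the scatter), so even this large change in the group at this carbon does not produce a step that can be told apart from the usual variation between repeats. The true size of the step stays uncertain because the starting point is a limit and not a number: the limit of < 5% in this assay, at which 2 of the 4 values shown sit.

The compounds shown leave open whether the nitrogen that links the group to the ring or the hexyl chain that it carries matters more, since both enter together in compound 4, and a plain amino group or a methylamino group on the same sugar and shared core would separate the two. They also leave open how the read-out follows chain length, which a butylamino or an octylamino group at this carbon would begin to show.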